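From propargyloxy to 3-(dimethylamino)propoxy on compound 2

The source may hold more compounds than are shown below. What is called first, only, known or untested is meant among the compounds shown, and "the series" means these compounds.

In a functional assay on SK-BR-3 cells (Homo sapiens) for antiproliferative activity (a lower number here means a stronger inhibitor, a higher number a weaker inhibitor), compound 2 (`C#CCOc1ccc(C(=O)Nc2cc3ccc(OC4CCN(C)CC4)c(C)c3oc2=O)cc1CC=C(C)C`) gives 1400 nM and stands within the scatter of compound 1 (`COc1ccc(C(=O)Nc2cc3ccc(OC4CCN(C)CC4)c(C)c3oc2=O)cc1CC=C(C)C`) at 1410 nM and of compound 3 (`C=CCc1cc(C(=O)Nc2cc3ccc(OC4CCN(C)CC4)c(C)c3oc2=O)ccc1OC(C)=O`) at 2260 nM alike. Compound 4 (`CC(C)=CCc1cc(C(=O)Nc2cc3ccc(OC4CCN(C)CC4)c(C)c3oc2=O)ccc1OCCCN(C)C`) carries 2-(dimethylamino)ethyl in place of ethynyl on a saturated chain carbon bound to an oxygen on an aromatic ring. Among the compounds with values here, the one measured step at this place is a 1.0-fold lower number from compound 1 to compound 2 (0.00 log units; within the scatter) and it lies within the scatter. Within the data shown here, no measured step brings in 2-(dimethylamino)ethyl, so the evidence is thin. An estimated step of a 1.2-fold lower number from compound 2 to compound 4 (0.07 log units; within the scatter) is expected in this assay and thus none beyond the scatter. For compound 4 the estimated value is 1200 nM with an expected range from 400 nM to 3500 nM in this measurement.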

Compound 4, half-maximal inhibitory concentration: 250 nM
Compound 4: middle estimate off by 4.8-fold (0.68 log units), on the high side; the whole stated range lies above it.
By their numbers in this assay, from the lowest: compound 4; then compounds 2, 1 and 3 (each within the scatter of the next).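

The earlier step at this place had stayed within the scatter, but in this assay the 3-(dimethylamino)propoxy group gives a 5.6-fold lower number from compound 2 to compound 4 (0.75 log units; beyond the scatter) and a 5.6-fold lower number from compound 1 to compound 4 (0.75 log units; beyond the scatter), so this position does respond to what it carries. Among the compounds shown, only compound 4 has a nitrogen in this chain. Nothing available accounts for this step. From the compounds shown here alone, it remains open whether the dimethylamino nitrogen or the chain length carries the step, which a 3-methoxypropoxy chain could separate. A shorter 2-(dimethylamino)ethoxy chain or a terminal morpholine would show how far the step extends.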